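Extending the Ring Nitrogen Substituent from Acetyl to Hexynyl

The compounds below may be only part of what the source reports. "The series", "measured", "known", "first", "only" and "open" are said of these compounds alone.

Measured compounds:
- compound 1, `CC(=O)N1CCC(c2ccc(-c3cc(C(=O)O)cc4cc(-c5ccc(C(F)(F)F)cc5)ccc34)cc2)CC1`: 100%
- compound 2, `O=C(O)c1cc(-c2ccc(C3CCNCC3)cc2)cc(-c2cn(-c3ccc(C(F)(F)F)cc3)nn2)c1`: 71.4%
- compound 3, `O=C(O)c1cc(O)c2ccc(-c3ccc(C(F)(F)F)cc3)cc2c1`: 59.8%

Of the compounds shown here, three have been tested in a functional assay on the whole organism (strain ICR) for inhibition, with Mus musculus as the target, with stated times of 7 days and 2 h, at a dose of 10 umol/kg by the intraperitoneal route; on this read-out lower numbers stand for less inhibition and higher numbers for more inhibition at the one dose given (going by the name of the read-out). Compound 1 gives 100% in this assay, the highest of the three numbers. Compound 2 stands closest to it, yet its value in this assay, 71.4%, lies beyond the scatter below compound 1. Compound 3 is the furthest away, with 59.8% in this assay, again beyond the scatter.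

The next compound, compound 4, `C#CCCCCN1CCC(c2ccc(-c3cc(C(=O)O)cc4cc(-c5ccc(C(F)(F)F)cc5)ccc34)cc2)CC1`, has not yet been measured. It differs from compound 1 in one place: hex-5-yn-1-yl in place of acetyl on an amine nitrogen in a ring. Going by the values given here, no pair of measured compounds differs in exactly one place, so no measured step can be carried over directly to this change. Among the compounds with values here, compound 2, the only other measured compound that carries an amine nitrogen in a ring, gives a lower number than compound 1, but it also differs from compound 1 elsewhere, so that pair shows only what its two values show.

Compound 4 is therefore expected to remain near the top of the range, with an estimated step of a number 15 percentage points lower from compound 1 to compound 4 (beyond the scatter) that is small or downward and may fall within the scatter. The estimate for compound 4 in this assay is 85%, with a range from 55% to 100%.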

Compound 4, a percentage reported as inhibition, in the whole organism at one dose (the size of the read-out at that dose, not a potency): 42.7%
For compound 4 the middle estimate is 42.3 percentage points above the measured one, outside the stated range (below it).
By their numbers in this assay, from the lowest: compound 4; then compound 3; then compound 2; then compound 1.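

In this assay the step of a number 57.3 percentage points lower from compound 1 to compound 4 (beyond the scatter) shows that the substituent on the amine nitrogen in the ring has a large bearing on the read-out, with the rest of compound 1 left unchanged. Going by these compounds alone, this is the first change in one place measured here, and it shows that the high number of compound 1 does not survive the replacement of acetyl by hex-5-yn-1-yl, a change that adds to the size of the substituent, replaces a double bond with a triple bond and removes a hydrogen-bond acceptor. No measurement here bears on why the number falls.

Which of these differences matters remains open, since a saturated hexyl chain, a small methyl group or a longer acyl group such as hexanoyl on the same nitrogen would separate chain length, the triple bond and the carbonyl. Also open, from the compounds shown here alone, is how the core of compound 1 behaves with only a hydrogen on that nitrogen, and whether the same replacement would have a similar effect on a different core.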